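A few compounds are considered here, and "the series" means these few. Any claim that something is new, unique, unknown or untested is made for them only; others in the source may bear on it.

Compound 1 `COC(=O)N[C@@H](CSC)C(=O)N1CCC[C@H]1c1ncc(-c2ccc(-c3ccc(-c4cnc([C@@H]5CCCN5C(=O)[C@@H](NC(=O)OC)C(C)C)[nH]4)cc3)cc2)[nH]1`: 11000 nM
Compound 2 `COC(=O)N[C@@H](CSC(C)(C)C)C(=O)N1CCC[C@H]1c1ncc(-c2ccc(-c3ccc(-c4cnc([C@@H]5CCCN5C(=O)[C@@H](NC(=O)OC)C(C)C)[nH]4)cc3)cc2)[nH]1`: 10000 nM

These two compounds were tested in an ADME assay on CCRF-CEM cells (Homo sapiens) for cytotoxicity; a higher number here means that more compound is tolerated, a lower number that less compound is tolerated. Within the data shown here, compound 1 gives 11000 nM, and the only number to set it against is that of compound 2, at 10000 nM. The two stand level, since the step between them lies within the scatter.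

Compound 3 `COC(=O)N[C@@H](CSCc1ccccc1)C(=O)N1CCC[C@H]1c1ncc(-c2ccc(-c3ccc(-c4cnc([C@@H]5CCCN5C(=O)[C@@H](NC(=O)OC)C(C)C)[nH]4)cc3)cc2)[nH]1` has not yet been measured in this assay. It differs from compound 1 as follows: phenyl in place of hydrogen on a saturated chain carbon bound to a sulfur. Read one bond further out, this turns methylsulfanyl into benzylsulfanyl.

Among the measured compounds shown here, one measured step bears on this change. It is a 1.1-fold lower number from compound 1 to compound 2 (0.04 log units; within the scatter), made at the same sulfur, with tert-butyl in place of methyl. For the measured compounds named here, that step stays within the scatter, but it is a single step and no measured compound carries a benzyl group, so the evidence is thin. No step beyond the scatter is therefore expected for compound 3, in either direction.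

The expected step is a 1.2-fold lower number from compound 1 to compound 3 (0.06 log units; within the scatter). For compound 3 the estimated value is 9500 nM, with an expected range of 4500 nM to 20000 nM.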

Compound 3, half-maximal cytotoxic concentration: 82000 nM
Estimate against measurement, compound 3: 8.6-fold (0.94 log units) below, and the stated range ends below it.
By their numbers in this assay, from the lowest: compounds 2 and 1 (each within the scatter of the next); then compound 3.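

In this assay, among these compounds, the group on the sulfur now makes a difference, with a 7.5-fold higher number from compound 1 to compound 3 (0.87 log units; beyond the scatter) on going from methylsulfanyl to benzylsulfanyl and an 8.2-fold higher number from compound 2 to compound 3 (0.91 log units; beyond the scatter) with benzyl in place of tert-butyl, while the one earlier step at this sulfur stayed within the scatter. Among the compounds shown here, the position is therefore not indifferent to what it carries: methyl and tert-butyl stand level, and only benzyl, the one group of the three with a six-membered aromatic ring of carbon only, stands apart from them. No evidence is at hand that would account for this difference.

The compounds shown leave open whether the aromatic ring itself is what counts, which a cyclohexylmethyl group on the same sulfur would help to settle. They also leave open whether a longer chain such as phenethyl, or a benzyl group carrying a carboxylic acid or an amine on its ring, would stay at the level of compound 3 or fall back towards that of compound 1.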